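Pyrazolopyridine amidines: benzyl in place of methyl

The source may hold more compounds than are shown below. What is called first, only, known or untested is meant among the compounds shown, and "the series" means these compounds.

Measured compounds:
compound 1 `COc1ccc(Cn2cc3cc(C(=N)Nc4ccccc4)ncc3n2)cc1` 2040 nM
compound 2 `CN1CCN(c2ccc(NC(=N)c3cc4cn(C)nc4cn3)cc2)CC1` 24800 nM
compound 3 `CN1CCN(c2ccc(NC(=N)c3cc4c(-c5ccccc5)nn(C)c4cn3)cc2)CC1` 5900 nM

In a functional assay on PC-3 cells (Homo sapiens) for cytotoxicity, read by MTT assay, with a stated time of 72 h (a lower number here means a stronger inhibitor, a higher number a weaker inhibitor), compound 2 gives 24800 nM, the highest number of the three. The nearest is compound 3 with 5900 nM, the furthest compound 1 with 2040 nM; both gaps lie beyond the scatter.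

Compound 4 `COc1ccc(Cn2cc3cc(C(=N)Nc4ccc(N5CCN(C)CC5)cc4)ncc3n2)cc1` differs from compound 2 as follows: 4-methoxyphenyl in place of hydrogen on a saturated chain carbon bound to an aromatic nitrogen

Among the compounds with values here, no step between measured pairs that differ in one place is available, so the direction rests on the pattern that compound 1, which also carries a 4-methoxyphenyl on that chain carbon, gives the lowest number. A decrease in number, beyond the scatter, is expected for compound 4 in this assay, a 6.2-fold lower number from compound 2 to compound 4 (0.79 log units; beyond the scatter). Compound 4 is estimated at 4000 nM, within 1500 nM to 12000 nM.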

Compound 4, half-maximal inhibitory concentration: 9900 nM
Compound 4: middle estimate off by 2.5-fold (0.39 log units), on the low side, within the range that was stated.
By their numbers in this assay, from the lowest: compound 1; then compounds 3 and 4 (each within the scatter of the next); then compound 2.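

The change of 4-methoxyphenyl in place of hydrogen on a saturated chain carbon bound to an aromatic nitrogen gives a 2.5-fold lower number from compound 2 to compound 4 (0.40 log units; beyond the scatter) in this assay, so the lower number now holds in a comparison that differs in one place, though the step is modest. With 4-methoxybenzyl kept, 4-methylpiperazin-1-yl in place of hydrogen on an aromatic carbon gives a 4.9-fold higher number from compound 1 to compound 4 (0.69 log units; beyond the scatter). No measurement at hand accounts for either step.

Open, as far as these compounds go, is whether the methoxy group matters, which an unsubstituted benzyl or a 4-fluorobenzyl would test. Also open, from the compounds shown here alone, is how a longer chain at this place would read.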